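This account rests on a few compounds, and the source may have more. Where it says the series, first, only, none or still open, it means among the compounds named here.

Measured so far in a functional assay on LOX IMVI cells (Homo sapiens) for inhibition, read by sulforhodamine B assay, with a stated time of 48 h; on this read-out higher numbers stand for weaker inhibition of growth and lower numbers for stronger inhibition of growth:
compound 1, `COc1cc2cc(Oc3ccc(NC(=O)Nc4cccc(C(F)(F)F)c4)cc3)c(C)nc2cc1OC`, gives 1840 nM;
compound 2, `COc1cc2cc(Oc3ccc(NC(=O)Nc4ccc(Cl)c(C(F)(F)F)c4)cc3)c(C)nc2cc1OC`, gives 1220 nM.

For the measured compounds named here, compound 2 stands at the lowest of the two numbers in this assay, and the only measured step, a 1.5-fold lower number from compound 1 to compound 2 (0.18 log units; within the scatter), lies within the scatter. Compound 3, `COc1cc2cc(Oc3ccc(NC(=O)Nc4ccc(Cl)c(Cl)c4)cc3)c(C)nc2cc1OC`, differs from compound 2 by chloro in place of trifluoromethyl on an aromatic carbon. Going by the values given here, no measured step exchanges trifluoromethyl for chloro; the one step known touches a different position and was small. The writer therefore expects no step beyond the scatter, a 1.2-fold higher number from compound 2 to compound 3 (0.09 log units; within the scatter), and estimates for compound 3 a value of 1500 nM, within 600 nM to 4000 nM.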

Compound 3, concentration for 50% growth inhibition: 3450 nM
Compound 3: the middle estimate sits 2.3-fold (0.36 log units) below what was measured, within the range that was stated.
By their numbers in this assay, from the lowest: compounds 2, 1 and 3 (each within the scatter of the next, the first and the last beyond it).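

In this assay, for the compounds shown here, trifluoromethyl gives way to chloro on this aromatic carbon, ortho to a chloro group, with a 2.8-fold higher number from compound 2 to compound 3 (0.45 log units; beyond the scatter), the only step here beyond the scatter, whereas the earlier step stayed within it. The change from 3-(trifluoromethyl)phenyl to 3,4-dichlorophenyl shows a 1.9-fold higher number from compound 1 to compound 3 (0.27 log units; within the scatter), so this comparison alone shows no clear change. Nothing available here explains the difference. From the compounds shown here alone, whether a nitrile or a methoxy group at this position would give a number nearer that of compound 2 or of compound 3 remains open, as does whether the step holds in other cell lines.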